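This account rests on a few compounds, and the source may have more. Where it says the series, first, only, none or still open, it means among the compounds named here.

Measured compounds:
- compound 1, `Cc1ccc2c(c1)N(C1=CCCC1=O)CC(C)(C)S2`: 89%
- compound 2, `CC1(C)CN(C2=CCCC2=O)c2cc(N)ccc2S1`: 96%

Both were tested in a functional assay on aorta (Rattus norvegicus, strain Wistar); a lower number here means a smaller maximal response, a higher number a larger maximal response. Within the data shown here, compound 2 stands at the higher of the two numbers, but its only neighbour, compound 1, lies just below it, and the one measured step, a number 7 percentage points higher from compound 1 to compound 2 (within the scatter), is within the scatter, so the two cannot be ranked.

Compound 3, `CCc1ccc2c(c1)N(C1=CCCC1=O)CC(C)(C)S2`, is not yet measured. It differs from compound 2 by ethyl in place of amino on an aromatic carbon. Among the measured compounds shown here, the one measured step bears on this directly: it went the other way, putting amino where methyl had been, and it stayed within the scatter. Ethyl is a chain of the same kind as methyl, so undoing the amino is expected to give back roughly the number of compound 1, that is a step of about a number 6 percentage points lower from compound 2 to compound 3 (within the scatter) from compound 2, within the scatter. Compound 3 is therefore estimated at 90% in this assay, with a range from 78% to 100%.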

Compound 3, largest response reached (Emax), in percent of the reference or control that the assay uses: 97%
For compound 3 the middle estimate is 7 percentage points below the measured one; the measured number falls inside the stated range.
By their numbers in this assay, from the lowest: compounds 1, 2 and 3 (each within the scatter of the next).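

In this assay, putting ethyl in place of amino on this aromatic carbon gives a number 1 percentage points higher from compound 2 to compound 3 (within the scatter), and adding methyl to the saturated chain carbon bound to the aromatic carbon gives a number 8 percentage points higher from compound 1 to compound 3 (within the scatter). This position has now carried methyl, amino and ethyl, which differ in heavy atoms and in hydrogen-bond donors and acceptors, yet the maximal responses of the three compounds cannot be told apart. Nothing available explains this result.

On these data alone, whether a carboxylic acid, a longer chain such as butyl or a halogen such as chlorine on this aromatic carbon would give a clearly different maximal response remains open. As far as these compounds go, all three compounds also share the rest of the core, so the part played by the other regions of the molecule is still unknown.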